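The source may hold more compounds than are shown below. What is called first, only, known or untested is meant among the compounds shown, and "the series" means these compounds.

Compound 1, `CC(C)Nc1nc(NCc2ccco2)c2ccccc2n1`, stands in a physicochemical assay for solubility, at pH 7.4 (on this read-out higher numbers stand for higher solubility and lower numbers for lower solubility), only at a limit of the assay, >= 30000 nM, and the two further values recorded in this read-out are limits as well. Compound 2, `OCCNc1nc(NCc2ccco2)c2ccccc2n1`, sits at the limit <= 20000 nM. Compound 3, `CC(C)Nc1nc(NCc2ccco2)c2cccc(Cl)c2n1`, sits at the limit <= 5000 nM. The exchange of 2-hydroxyethyl for isopropyl gives an at least 1.5-fold lower number from compound 1 to compound 2 (0.17 log units; that floor lies within the scatter). Compound 4, `CC(C)Nc1nc(NCc2ccco2)c2c(Cl)cccc2n1`, differs from compound 1 by chloro in place of hydrogen on an aromatic carbon. Of the measured steps, the one that bears on this change is an at least 6.0-fold lower number from compound 1 to compound 3 (0.77 log units; beyond the scatter), the same exchange of hydrogen for chloro on an aromatic carbon, at least modest in size and downward. A decrease of comparable size is therefore expected for compound 4, an at least 6.0-fold lower number from compound 1 to compound 4 (0.77 log units; beyond the scatter). Compound 4 is accordingly estimated at 5000 nM, within 1500 nM to 20000 nM.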

Compound 4, solubility: <= 10000 nM
Compound 4 ended at the assay's limit; the forecaster's own chance of this, stated with the estimate: 60%; the middle value lies beyond the limit too.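

With chloro on an aromatic carbon ortho to a fused ring, the step in this assay is an at least 3.0-fold lower number from compound 1 to compound 4 (0.47 log units; beyond the scatter). A downward step beyond the scatter is therefore not confined to the chloro position of compound 3, and it appears at this second aromatic carbon as well. Compound 3 and compound 4 both stand only at limits, so the two chloro positions cannot be ordered.

From the compounds shown here alone, how far the number falls below this floor stays open. So does whether a methoxy group or an amine on this carbon would move the number in the same direction.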